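The compounds below may be only part of what the source reports. "The series", "measured", "known", "first", "only" and "open" are said of these compounds alone.

Measured in a functional assay on MCF7 cells (Homo sapiens) for antiproliferative activity, read by CCK-8 assay, with a stated time of 72 h; a higher number here means a weaker inhibitor of growth, a lower number a stronger inhibitor of growth:
- compound 1 `CCC1C(=O)N(C)c2cnc(Nc3ccc(S(=O)(=O)NCCO)cc3)nc2N1c1ccn(C)n1`: "not active" (no number reported)
- compound 2 `CCC1C(=O)N(C)c2cnc(-n3ccc4cc(F)ccc43)nc2N1c1ccn(C)n1`: 24700 nM
- compound 3 `CC[C@@H]1C(=O)N(C)c2cnc(Nc3ccc(S(=O)(=O)NCCO)cc3)nc2N1C1CCCC1`: 344 nM

Of the two numbers in this assay, compound 2 has the higher, and the gap down to compound 3 lies beyond the scatter. Compound 1 gives no number to compare. Compound 4 `CCC1C(=O)N(C)c2cnc(-n3ccc4cc(C(N)=O)ccc43)nc2N1c1ccn(C)n1` carries carbamoyl in place of fluoro on an aromatic carbon. Going by the values given here, no measured pair shows this change, so the expectation is loose. A modest move towards a lower number is expected, perhaps not beyond the scatter, and a result without a number remains possible. The expected step is a 2.1-fold lower number from compound 2 to compound 4 (0.31 log units; beyond the scatter). For compound 4 the estimate is 12000 nM, with an expected range of 2500 nM to 50000 nM.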

Compound 4, concentration for 50% growth inhibition: "not active" (no number reported)
For compound 4 the study gives words and no number, so the estimate cannot be set against anything.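

Compound 4 gives "not active" (no number reported) and so offers no number to set against compound 2, and no step can be read. No evidence bears on this result. On these data alone, how far carbamoyl in place of fluoro moves growth inhibition stays open.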